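Chlorophenyl Ether Replacing a Difluorophenyl Ether

The source may hold more compounds than are shown below. What is called first, only, known or untested is meant among the compounds shown, and "the series" means these compounds.

Compound 3, `Cc1cn(C2CCN(Cc3cccc(Oc4cc(F)cc(F)c4)c3)CC2)c(=O)[nH]c1=O`, is the starting point. In an ADME assay on MRC5 cells (Homo sapiens) for cytotoxicity, read by fluorescence and resazurin assay, with a stated time of 3 days (a higher number here means a weaker inhibitor, a lower number a stronger inhibitor), compound 3 gives only a limit of the assay, > 64000 nM, which is the limit of > 64000 nM in this assay, at which 2 of the 3 values shown sit. Compound 1, `Cc1cccc(Oc2cccc(CN3CCC(n4cc(C)c(=O)[nH]c4=O)CC3)c2)c1`, likewise gives only a limit in this assay, > 64000 nM. Compound 2, `Cc1cn(C2CCN(Cc3cccc(OC4CCCCC4)c3)CC2)c(=O)[nH]c1=O`, gives a number in this assay, 23600 nM. Among the measured compounds shown here, the step of an at least 2.7-fold higher number from compound 2 to compound 3 (0.43 log units; beyond the scatter) is the only readable step touching compound 3, while the step that the two limits leave unreadable from compound 1 to compound 3 cannot be sized. Compound 4, `Cc1cn(C2CCN(Cc3cccc(Oc4ccc(Cl)cc4)c3)CC2)c(=O)[nH]c1=O`, differs from compound 3 by 4-chlorophenyl in place of 3,5-difluorophenyl on an oxygen on an aromatic ring. Since compound 1 and compound 3 both sit at the limit, compound 4 is expected to stay near that limit, the expected step being a number no higher from compound 3 to compound 4 (the limit leaves the size open). Compound 4 is estimated at 64000 nM, between 30000 nM and 150000 nM.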

Compound 4, half-maximal inhibitory concentration: 25100 nM
Compound 4: middle estimate off by 2.5-fold (0.41 log units), on the high side; measured number outside the range, below it.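

In this assay, a phenyl ring on this oxygen does not by itself keep a compound at the limit: 4-chlorophenyl gives an at least 2.5-fold lower number from compound 3 to compound 4 (0.40 log units; beyond the scatter) and an at least 2.5-fold lower number from compound 1 to compound 4 (0.40 log units; beyond the scatter). Against the cyclohexyl ether, the change gives a 1.1-fold higher number from compound 2 to compound 4 (0.03 log units; within the scatter), so these two groups are not told apart here. The two lower steps give only minimum sizes, because compound 1 and compound 3 each stand at a limit: the limit of > 64000 nM in this assay, at which 2 of the 4 values shown sit.

The compounds shown do not separate the effect of the chlorine from that of its place on the ring. From the compounds shown here alone, how a phenyl ring carrying an amine or a carboxylic acid would read here stays open.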